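Ester and aryl substituent effects on microsomal stability

This account rests on a few compounds, and the source may have more. Where it says the series, first, only, none or still open, it means among the compounds named here.

Compound 1 `CCCCc1nc(C)c(CC(=O)OC)c(=O)n1Cc1ccc(-c2ccccc2-c2noc(=O)[nH]2)cc1`, compound 2 `CCCCc1nc(C)c(CC(=O)OC(C)C)c(=O)n1Cc1ccc(-c2ccccc2-c2noc(=O)[nH]2)cc1` and compound 3 `CCCCc1nc(C2CC2)c(CC(=O)OC)c(=O)n1Cc1ccc(-c2ccccc2-c2noc(=O)[nH]2)cc1` share one core. In an ADME assay on microsomes from liver (Mus musculus) for metabolic stability, with a stated time of 30 min (a higher number here means that more of the compound is left, a lower number that less of the compound is left), compound 1 gives 47.1%, compound 2 gives 4% and compound 3 gives 16.4%. Compound 3 thus stands second of the three measured numbers, beyond the scatter from each of the other two. The measured steps run a number 43.1 percentage points lower from compound 1 to compound 2 (beyond the scatter) and a number 30.7 percentage points lower from compound 1 to compound 3 (beyond the scatter). Compound 4 `CCCCc1nc(C2CC2)c(CC(=O)OC(C)C)c(=O)n1Cc1ccc(-c2ccccc2-c2noc(=O)[nH]2)cc1` differs from compound 3 by isopropyl in place of methyl on an oxygen next to a carbonyl group, the same change that separates compound 1 from compound 2. Because that step, a number 43.1 percentage points lower from compound 1 to compound 2 (beyond the scatter), was large and downward, a downward step is expected here too, a number 13.4 percentage points lower from compound 3 to compound 4 (beyond the scatter), limited by the floor of the read-out. Compound 4 is expected to give 3% in this assay, within a range from 0% to 12%.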

Compound 4, percent of the compound remaining: 14%
Estimate against measurement, compound 4: 11 percentage points below; measured number outside the range, above it.
By their numbers in this assay, from the lowest: compounds 2, 4 and 3 (each within the scatter of the next, the first and the last beyond it); then compound 1.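

Within the data shown here, with cyclopropyl on the aromatic carbon, isopropyl in place of methyl on an oxygen next to a carbonyl group no longer separates the compounds in this assay, giving a number 2.4 percentage points lower from compound 3 to compound 4 (within the scatter). The size of this change thus depends on the group at the aromatic carbon: the same change on two cores in this assay, a number 43.1 percentage points lower (beyond the scatter) from compound 1 to compound 2 and a number 2.4 percentage points lower (within the scatter) from compound 3 to compound 4, 40.7 percentage points apart, beyond the scatter of two such steps. Conversely, with isopropyl on that oxygen, cyclopropyl in place of methyl on an aromatic carbon gives a number 10 percentage points higher from compound 2 to compound 4 (within the scatter), so this change likewise depends on its partner: the same change on two cores in this assay, a number 30.7 percentage points lower (beyond the scatter) from compound 1 to compound 3 and a number 10 percentage points higher (within the scatter) from compound 2 to compound 4, 40.7 percentage points apart, beyond the scatter of two such steps.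

Going by these compounds, whether ethyl or tert-butyl on that oxygen, or a carboxylic acid in place of the ester, would follow the methyl or the isopropyl compounds remains open. Also open, on these data alone, is how ethyl on the aromatic carbon would behave.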